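The source may hold more compounds than are shown below. What is called first, only, known or untested is meant among the compounds shown, and "the series" means these compounds.

Compound 1 `CC(=O)/C(=N\Nc1ccccc1)Oc1cccc(Cl)c1` — > 10000 nM
Compound 2 `CC(=O)/C(=N\Nc1ccccc1C(F)(F)F)N(C)c1cccc(Cl)c1` — > 10000 nM

In an assay on isolated protein for binding affinity to corticotropin-releasing factor receptor 1 (Homo sapiens) (on this read-out lower numbers stand for stronger inhibition and higher numbers for weaker inhibition), compound 1 gives > 10000 nM, which is a limit of the assay and not a measured number. Compound 2 likewise reaches only > 10000 nM in this assay, again a limit. Everything measured so far rests at the limit of > 10000 nM in this assay, at which 2 of the 2 values shown sit, so compound 1 has no position among real numbers, only a ceiling.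

Compound 3 `CC(=O)/C(=N\Nc1ccccc1C)Oc1cccc(Cl)c1` differs from compound 1 by methyl in place of hydrogen on an aromatic carbon, a methyl in place of hydrogen on an aromatic carbon, the phenyl becoming 2-methylphenyl. Going by the values given here, no step between measured compounds is available to guide this change, and with compound 1 itself sitting at a limit, the author expects the step from compound 1 to compound 3 to be a step that the limit leaves unreadable from compound 1 to compound 3, nothing beyond the scatter in either direction. Compound 3 is therefore estimated at 20000 nM in this assay. The expected range for compound 3 runs from 3000 nM to 100000 nM, most likely again reported only as a limit.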

Compound 3, inhibition constant: > 10000 nM
Compound 3 was reported as a limit (the forecaster's own chance of this, stated with the estimate: 80%); the middle value lies beyond the limit too.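

Going by these compounds alone, compound 1 and compound 3 both stand only at a limit, so methyl in place of hydrogen on an aromatic carbon gives no step that can be read: the limit of > 10000 nM in this assay, at which 3 of the 3 values shown sit. The compounds shown leave open whether any relative of this series reaches a real number in this assay.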